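Swapping a chloro for a methyl on a coumarin anilide

The source may hold more compounds than are shown below. What is called first, only, known or untested is meant among the compounds shown, and "the series" means these compounds.

Three amides built on one shared core have been measured in an in vitro assay on BTI-TN-5B1-4 cells for inhibition of Amine oxidase [flavin-containing] B (Homo sapiens), read by fluorescence; on this read-out lower numbers stand for stronger inhibition and higher numbers for weaker inhibition. Compound 1 `O=C(Nc1ccccc1)c1cc2ccccc2oc1=O` gives 760 nM. Compound 2 `CSc1ccc(NC(=O)c2cc3ccccc3oc2=O)cc1` gives 2840 nM, and a 3.7-fold higher number from compound 1 to compound 2 (0.57 log units; beyond the scatter). Compound 3 `Cc1cccc(Cl)c1NC(=O)c1cc2ccccc2oc1=O` gives 19100 nM, the highest of the three numbers; the step up from compound 2 to compound 3 and the larger one from compound 1 to compound 3 both lie beyond the scatter.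

Compound 4 `Cc1cccc(C)c1NC(=O)c1cc2ccccc2oc1=O` is the next compound, not yet measured. It differs from compound 3 by methyl in place of chloro on an aromatic carbon. Among the compounds with values here, no measured step covers this change: the only step measured so far, from compound 1 to compound 2, concerns a methylsulfanyl at a different place. Within the data shown here, the values of compound 1 and compound 3 show only that the two groups flanking the amide nitrogen in compound 3 go with a much higher number. Exchanging one of them for a group of the same size is expected to leave things roughly where they are, so the expected step is a 1.3-fold lower number from compound 3 to compound 4 (0.10 log units; within the scatter). Compound 4 is therefore estimated at 15000 nM, within a range of 5000 nM to 45000 nM.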

Compound 4, half-maximal inhibitory concentration: 1290 nM
Beside the measured number, compound 4's estimate is 12-fold (1.07 log units) above it; the whole stated range lies above it.
By their numbers in this assay, from the lowest: compounds 1 and 4 (each within the scatter of the next); then compound 2; then compound 3.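

In this assay, putting methyl in place of chloro on this aromatic carbon, ortho to a large group, gives a 15-fold lower number from compound 3 to compound 4 (1.17 log units; beyond the scatter) and so lands far beyond the scatter, although each group counts as 1 heavy atom. Within the data shown here, the earlier compounds could not show this: their only step concerns a methylsulfanyl, and compound 3 alone could not separate the effect of its chloro from that of the methyl that stays in place in compound 4. So at this position, the identity of the group matters, not just the presence of a group of that heavy-atom count, but nothing available explains the size of this step.

Going by these compounds, whether a fluoro, a methoxy or an amine at this place would behave like the chloro or like the methyl remains open. Also open, on these data alone, is whether changing the remaining methyl would move the number as far.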